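The source may hold more compounds than are shown below. What is called first, only, known or untested is meant among the compounds shown, and "the series" means these compounds.

Compound 1 `COc1cc(Cl)cc(-c2nn(-c3cccc(NC(=O)c4ccc(Cl)c(Cl)c4)c3)cc2-c2ccncc2)c1`: 80.8%
Compound 2 `O=C(Nc1cccc(-n2cc(-c3ccncc3)c(-c3cc(O)cc(Cl)c3)n2)c1)Nc1ccc(Cl)c(C(F)(F)F)c1`: 9.57%

In a functional assay on MDA-MB-435 cells (Homo sapiens) for inhibition, read by sulforhodamine B assay, with a stated time of 48 h, tested at 10 uM (on this read-out lower numbers stand for a stronger effect and higher numbers for a weaker effect at the one concentration tested), compound 1 gives 80.8%, while compound 2 gives 9.57%. Of the two numbers, compound 2 stands lowest; compound 1 lies a long way higher, a gap well beyond the scatter. The two compounds differ in more than one place, so the gap shows only what the two values show, and no single change can be read from it.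

Compound 3 `O=C(Nc1cccc(-n2cc(-c3ccncc3)c(-c3cc(O)cc(Cl)c3)n2)c1)Nc1ccc(Cl)c(Cl)c1` is the next compound and differs from compound 2 in one place: chloro in place of trifluoromethyl on an aromatic carbon. Within the data shown here, with no comparable step available, the expected step in this assay is small, either no change beyond the scatter or a modest rise, so that compound 3 is expected to move from compound 2 by a number 5.4 percentage points higher from compound 2 to compound 3 (within the scatter). Compound 3 is accordingly estimated at 15%, with a range from 4% to 40%, because compound 2 gives 9.57%.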

Compound 3, a percentage reported as activity, at one concentration (the size of the read-out at that concentration, not a potency): -33.3%
Compound 3: middle estimate off by 48.3 percentage points, on the high side, outside the stated range (below it).
By their numbers in this assay, from the lowest: compound 3; then compound 2; then compound 1.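

In this assay, among these compounds, the exchange of trifluoromethyl for chloro on this aromatic carbon, ortho to a chloro group, is the first change here that can be read on its own, and it is a large one (a number 42.9 percentage points lower from compound 2 to compound 3 (beyond the scatter)). The earlier pair could not show that this position responds at all, whereas compound 3 (-33.3%) shows that going from 4-chloro-3-(trifluoromethyl)phenyl to 3,4-dichlorophenyl moves the read-out further towards a stronger effect, to a negative number. Nothing available explains the size of this step.

On these data alone, what a bromo, a methyl or a nitrile on the same carbon would give remains open. So does whether the same exchange gives a step of this size when the rest of the molecule carries other groups.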